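Swapping a Fluorophenyl for a Cyclopropylcarbonyl on a Shared Core

This account rests on a few compounds, and the source may have more. Where it says the series, first, only, none or still open, it means among the compounds named here.

Compound 2 `COc1cc(-c2nnc(SCc3ccc(F)cc3)n2-c2ccc(N(C)C)cc2)cc(OC)c1OC` carries a 4-fluorobenzyl group on its sulfur. In a functional assay on HCT-116 cells (Homo sapiens) for inhibition, read by MTT assay, with a stated time of 48 h (a higher number here means a weaker inhibitor, a lower number a stronger inhibitor), compound 2 gives only a limit, > 60000 nM, so no number is known for it. Compound 1 `COc1cc(-c2nnc(SC)n2-c2ccc(N(C)C)cc2)cc(OC)c1OC` differs from compound 2 only at that sulfur-bound chain carbon. In this assay compound 1 likewise gives only a limit, > 60000 nM. The step that the two limits leave unreadable from compound 1 to compound 2 therefore cannot be read, since the limit of > 60000 nM in this assay, at which 2 of the 2 values shown sit, covers both values shown. Compound 3 `COc1cc(-c2nnc(SCC(=O)C3CC3)n2-c2ccc(N(C)C)cc2)cc(OC)c1OC` differs from compound 2 in one place: cyclopropylcarbonyl in place of 4-fluorophenyl on a saturated chain carbon bound to a sulfur. Within the data shown here, only the step from compound 1 to compound 2 touches the same place, and it gives no readable size, so it cannot point to a direction for this change beyond the scatter. The expected outcome is that compound 3 also fails to show measurable inhibition, with a step that the limit leaves unreadable from compound 2 to compound 3 that is expected to be small. The estimate for compound 3 in this assay is 80000 nM, with a range from 30000 nM to 200000 nM, most likely reported again only as a limit.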

Compound 3, half-maximal inhibitory concentration: > 60000 nM
Compound 3 was reported as a limit; the forecaster's own chance of this, stated with the estimate: 75%; the middle value lies beyond the limit too.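

In this assay compound 3 gives > 60000 nM, which is a limit and not a number. No size can therefore be read for any step among compound 1, compound 2 and compound 3: the limit of > 60000 nM in this assay, at which 3 of the 3 values shown sit. The compounds shown leave open whether any group on the sulfur of the shared core gives measurable inhibition.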